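The source may hold more compounds than are shown below. What is called first, only, known or untested is meant among the compounds shown, and "the series" means these compounds.

Compound 1 `COc1ccc(-c2nnc(-n3[se]c4ccccc4c3=O)s2)cc1`: 5930 nM
Compound 2 `O=c1c2ccccc2[se]n1-c1nnc(-c2cc([N+](=O)[O-])cc([N+](=O)[O-])c2)s1`: 17900 nM
Compound 3 `COc1ccccc1-c1nnc(-n2[se]c3ccccc3c2=O)s1`: 3120 nM

All three were tested in a functional assay on A549 cells (Homo sapiens) for antiproliferative activity, read by CCK-8 assay, with a stated time of 48 h; on this read-out lower numbers stand for stronger inhibition and higher numbers for weaker inhibition. Among these three numbers, compound 1 gives the second highest. Compound 3 gives a number close to it, within the usual scatter, so the two cannot be told apart; compound 2 gives a higher number, a gap that lies beyond the scatter. Compound 4 `Cc1ccc(-c2nnc(-n3[se]c4ccccc4c3=O)s2)cc1` has not yet been measured. It differs from compound 1 by methyl in place of methoxy on an aromatic carbon, a methyl in place of methoxy on an aromatic carbon. Among the measured compounds shown here, no measured pair here shows a change of this kind, so only a small step is expected, a 1.1-fold lower number from compound 1 to compound 4 (0.03 log units; within the scatter), one that may well stay within the scatter in either direction. Compound 4 is therefore expected to give about 5500 nM, somewhere between 2200 nM and 14000 nM.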

Compound 4, half-maximal inhibitory concentration: 13400 nM
Beside the measured number, compound 4's estimate is 2.4-fold (0.39 log units) below it; the range from low to high includes it.
By their numbers in this assay, from the lowest: compounds 3 and 1 (each within the scatter of the next); then compounds 4 and 2 (each within the scatter of the next).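

Replacing methoxy with methyl on this aromatic carbon, para to a large group, is not a neutral swap in this assay: the change gives a 2.3-fold higher number from compound 1 to compound 4 (0.35 log units; beyond the scatter) and so weakens inhibition. Among the compounds shown here, this is the first single-place comparison in the set, and it shows that the group at this position can shift the read-out. No measured evidence here accounts for the step.

The compounds shown leave open how an amine, a chlorine atom or a longer chain would compare with methoxy at this position. As far as these compounds go, whether the same swap would have a similar effect on compound 3 also remains unknown.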